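Swapping the sulfonyl aryl group: chloro-methoxyphenyl for cyanophenyl

This account rests on a few compounds, and the source may have more. Where it says the series, first, only, none or still open, it means among the compounds named here.

Measured compounds:
compound 1 `COc1ccc(S(=O)(=O)c2cnc3ccc(F)cc3c2N2CCC(C)CC2)cc1`, 85%
compound 2 `CC1CCN(c2c(S(=O)(=O)c3ccc(C#N)cc3)cnc3ccc(F)cc23)CC1`, 75%

Going by the values given here, in an assay on isolated protein for displacement of a labelled ligand from metabotropic glutamate receptor 5 (Homo sapiens), with a stated time of 60 min, tested at 1 uM (a lower number here means less inhibition, a higher number more inhibition at the concentration tested (going by the name of the read-out)), compound 2 gives 75%, the lower of the two numbers so far, with compound 1 at 85%; the two sit within the usual scatter of each other, so the two numbers are level. Compound 3 `COc1ccc(S(=O)(=O)c2cnc3ccc(F)cc3c2N2CCC(C)CC2)cc1Cl` is not yet measured. It differs from compound 2 in one place: 3-chloro-4-methoxyphenyl in place of 4-cyanophenyl on a sulfonyl sulfur. Among the compounds with values here, only one measured step bears on this change, the one from compound 1 to compound 2, where cyano took the place of methoxy on an aromatic carbon: a number 10 percentage points lower from compound 1 to compound 2 (within the scatter). Going from compound 2 to compound 3 reverses that exchange, returning the methoxy, and adds a chlorine on the same ring; no measured pair shows what that added chlorine does. Within the data shown here, since the one relevant step stayed within the scatter, no change beyond the scatter is expected, and the number for compound 3 is expected to sit close to that of compound 1. The expected step is a number 10 percentage points higher from compound 2 to compound 3 (within the scatter). For compound 3 the estimate in this assay is 85%, with a range from 65% to 96%.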

Compound 3, a percentage reported as inhibition, at one concentration (the size of the read-out at that concentration, not a potency): 82%
For compound 3 the middle estimate is 3 percentage points above the measured one; the measured number falls inside the stated range.
By their numbers in this assay, from the lowest: compounds 2, 3 and 1 (each within the scatter of the next).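

In this assay, going by these compounds alone, the new information concerns the added chlorine: with chloro in place of hydrogen on an aromatic carbon, the data show a number 3 percentage points lower from compound 1 to compound 3 (within the scatter), the first measured pair to isolate this change. The full exchange of 4-cyanophenyl for 3-chloro-4-methoxyphenyl on a sulfonyl sulfur gives a number 7 percentage points higher from compound 2 to compound 3 (within the scatter), so all three aryl groups tried at this position leave the read-out level, with no step beyond the scatter. Nothing available explains why these numbers stay level.

On these data alone, all three compounds carry a substituted phenyl group on the sulfonyl sulfur, so it remains open whether a carboxylic acid or an amine on that ring, or a plain alkyl chain in place of the ring, would keep the read-out level or move it beyond the scatter. As far as these compounds go, each number also gives the size of the inhibition at one concentration rather than a potency, so differences between these compounds that would appear across a range of concentrations remain open as well.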